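A few compounds are considered here, and "the series" means these few. Any claim that something is new, unique, unknown or untested is made for them only; others in the source may bear on it.

Measured so far:
Compound 1, `CCN1CCCC1CNC(=O)c1cc(N(C)S(C)(=O)=O)c(C)cc1OC`, in a functional assay on the whole organism for inhibition, with Canis familiaris (Canis lupus familiaris) as the target (a higher number here means that more compound is needed for the effect, a lower number that less compound is needed), gives 1 mg/kg.
Compound 2, `CCN1CCCC1CNC(=O)c1cc(N(C)S(C)(=O)=O)c(Cl)cc1OC`, gives 0.1 mg/kg.
Compound 3, `CCN1CCCC1CNC(=O)c1cc(NS(N)(=O)=O)c(C)cc1OC`, reaches only a limit of > 1 mg/kg.

Compound 1 and compound 2 differ by chloro in place of methyl on an aromatic carbon, and this gives a 10-fold lower number from compound 1 to compound 2 (1.00 log units; beyond the scatter). Compound 1 and compound 3 differ in their cores by sulfamoylamino in place of methyl(methylsulfonyl)amino on an aromatic carbon; a number no lower from compound 1 to compound 3 (the limit leaves the size open), because compound 3 sits at the limit of > 1 mg/kg in this assay, at which 1 of the 3 values shown sits.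

Compound 4, `CCN1CCCC1CNC(=O)c1cc(NS(N)(=O)=O)c(Cl)cc1OC`, is not yet measured. It differs from compound 3 by chloro in place of methyl on an aromatic carbon, the same kind of change as from compound 1 to compound 2, though here the chloro stands ortho to a sulfamoylamino group rather than ortho to a methyl(methylsulfonyl)amino group. Resting on a 10-fold lower number from compound 1 to compound 2 (1.00 log units; beyond the scatter), the expected step in this assay is an at least 2.0-fold lower number from compound 3 to compound 4 (0.30 log units; that floor lies within the scatter). Compound 4 is therefore estimated at 0.5 mg/kg, with a likely range from 0.1 mg/kg to 3 mg/kg.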

Compound 4, dose for half-maximal effect: 1 mg/kg
The estimate for compound 4 lay 2.0-fold (0.30 log units) below the measured number; measured number inside the range.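

In this assay the change to sulfamoylamino from methyl(methylsulfonyl)amino now has a readable size on the chloro-bearing core, giving a 10-fold higher number from compound 2 to compound 4 (1.00 log units; beyond the scatter). On the methyl-bearing core the same change gives a number no lower from compound 1 to compound 3 (the limit leaves the size open), so the data do not show whether it carries over unchanged: the same change on two cores in this assay, a number no lower (the limit leaves the size open) from compound 1 to compound 3 and a 10-fold higher number (1.00 log units; beyond the scatter) from compound 2 to compound 4; the limit leaves it open whether they differ. The step from methyl to chloro on the sulfamoylamino core gives a number no higher from compound 3 to compound 4 (the limit leaves the size open), which leaves its transfer from the core of compound 1 undecided: the same change on two cores in this assay, a 10-fold lower number (1.00 log units; beyond the scatter) from compound 1 to compound 2 and a number no higher (the limit leaves the size open) from compound 3 to compound 4; the limit leaves it open whether they differ.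

The compounds shown leave open how a bromo or a trifluoromethyl group would read in place of the chloro. They also leave open how an acetylamino group would read in place of the sulfamoylamino group.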